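Benzyloxy in Place of Nitro: Expected Loss of Potency

A few compounds are considered here, and "the series" means these few. Any claim that something is new, unique, unknown or untested is made for them only; others in the source may bear on it.

Measured compounds:
Compound 1 `COc1ccc(-c2sccc2-c2cc(OC)c(OC)c(OC)c2)cc1[N+](=O)[O-]` in a functional assay on HT-1080 cells (Homo sapiens) for antiproliferative activity, read by MTT assay, with a stated time of 72 h; a higher number here means a weaker inhibitor, a lower number a stronger inhibitor: 2100 nM
Compound 2 `COc1ccc(-c2sccc2-c2cc(OC)c(OC)c(OC)c2)cc1OCc1ccccc1` in this assay: compound 2 reaches only a limit of the assay, > 100000 nM
Compound 3 `CCOC(=O)c1cc(-c2ccc(OC)c([N+](=O)[O-])c2)c(-c2cc(OC)c(OC)c(OC)c2)s1` in this assay: 26100 nM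

The change from compound 1 to compound 2 is benzyloxy in place of nitro on an aromatic carbon. It gave an at least 47-fold higher number from compound 1 to compound 2 (1.67 log units; beyond the scatter), and the value for compound 2 is a limit of the assay, namely (the limit of > 100000 nM in this assay, at which 1 of the 3 values shown sits).

Compound 3 gives the highest number among the two numbers that are known here. The difference between the core of compound 3 and the core of compound 1 is not broken down here.

Compound 4 `CCOC(=O)c1cc(-c2ccc(OC)c(OCc3ccccc3)c2)c(-c2cc(OC)c(OC)c(OC)c2)s1` is not yet measured. It differs from compound 3 by benzyloxy in place of nitro on an aromatic carbon, the same change, at the same place, as that from compound 1 to compound 2.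

Because the earlier step gave an at least 47-fold higher number from compound 1 to compound 2 (1.67 log units; beyond the scatter), and because compound 3 already starts from 26100 nM, compound 4 is expected to show a step of about a 7.7-fold higher number from compound 3 to compound 4 (0.88 log units; beyond the scatter) in this assay. For compound 4 the estimate is therefore 200000 nM, with a range from 60000 nM to 1000000 nM, and it is expected that the assay most likely reports only a limit.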

Compound 4, half-maximal inhibitory concentration: > 100000 nM
Compound 4: a limit, no number; the forecaster's own chance of this, stated with the estimate: 80%; the middle value does not contradict the limit.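

In this assay, benzyloxy in place of nitro on an aromatic carbon gave an at least 3.8-fold higher number from compound 3 to compound 4 (0.58 log units; beyond the scatter), so on the two cores shown the change moves the number in the same direction, and on both the step lies beyond the scatter. Compound 4 gives only a limit of the assay, > 100000 nM. This shows that the loss seen on the core of compound 1 also appears on the core of compound 3, but it does not show that the loss is of the same size on the two cores, nor does it reach beyond these two cores: the same change on two cores in this assay, an at least 47-fold higher number (1.67 log units; beyond the scatter) from compound 1 to compound 2 and an at least 3.8-fold higher number (0.58 log units; beyond the scatter) from compound 3 to compound 4; the limit leaves it open whether they differ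

The compounds shown carry only nitro or benzyloxy at this place, which leaves open how an amine or a hydroxyl group there would read in this assay. They also leave open whether a carboxylic acid or an amide in place of the ethyl ester would change the number on the core of compound 3.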